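A few compounds are considered here, and "the series" means these few. Any claim that something is new, unique, unknown or untested is made for them only; others in the source may bear on it.

Measured compounds:
- compound 1 `COc1ccccc1-c1cc(=O)c2c(O)cc(OCCCCN3CCN(C)CC3)c(OC)c2o1` — 2330 nM
- compound 2 `COc1c(OCCCCN2CCN(C)CC2)cc(O)c2c(=O)cc(-c3ccc(F)cc3)oc12` — 2810 nM

Among the compounds with values here, in a functional assay on HepG2 cells (Homo sapiens) for cytotoxicity, read by MTT assay, with a stated time of 72 h (on this read-out lower numbers stand for stronger inhibition and higher numbers for weaker inhibition), compound 2 gives 2810 nM, and it stands next to compound 1, the only other number: the step of a 1.2-fold higher number from compound 1 to compound 2 (0.08 log units; within the scatter) lies within the scatter, so the two cannot be told apart. Compound 3 `COc1c(OCCCCN2CCN(C)CC2)cc(O)c2c(=O)cc(-c3ccc(F)cc3Br)oc12` carries bromo in place of hydrogen on an aromatic carbon. Within the data shown here, no measured step adds a bromo group; the one step measured, an exchange of the whole aryl group, stayed within the scatter. The expectation for compound 3 is therefore a step of a 1.0-fold lower number from compound 2 to compound 3 (0.00 log units; within the scatter), no larger than the scatter, giving an estimated value of 2800 nM with a range from 1300 nM to 6000 nM.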

Compound 3, half-maximal inhibitory concentration: 2130 nM
Estimate against measurement, compound 3: 1.3-fold (0.12 log units) above; the measured number falls inside the stated range.
By their numbers in this assay, from the lowest: compounds 3, 1 and 2 (each within the scatter of the next).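

Adding a bromo group to the 4-fluorophenyl ring gives only a small step in this assay (a 1.3-fold lower number from compound 2 to compound 3 (0.12 log units; within the scatter)), so at this place, ortho to a large group, one added bromine leaves the number within the scatter. Exchanging the whole aryl group for 2-bromo-4-fluorophenyl also stays within the scatter (a 1.1-fold lower number from compound 1 to compound 3 (0.04 log units; within the scatter)). Nothing available explains why these numbers stay so close.

Going by these compounds, whether a chloro group, an amine or a carboxylic acid at this place would move the number beyond the scatter remains open.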